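This account rests on a few compounds, and the source may have more. Where it says the series, first, only, none or still open, it means among the compounds named here.

The measured compounds:
compound 1 `OC[C@H]1O[C@@H](n2cnc3c(CSCc4ccccc4)ncnc32)[C@H](O)[C@@H]1O` — in a functional assay on Huh-7 cells (Homo sapiens) for cytotoxicity, read by MTT assay, with a stated time of 3 days (a higher number here means that more compound is tolerated, a lower number that less compound is tolerated), compound 1 gives > 100000 nM, a limit of the assay.
compound 2 `CC(=O)N(Cc1ncnc2c1ncn2[C@@H]1O[C@H](CO)[C@@H](O)[C@H]1O)C1CCCCC1` — compound 2 gives > 100000 nM, also a limit.
compound 3 `COCc1ncnc2c1ncn2[C@@H]1O[C@H](CO)[C@@H](O)[C@H]1O` — compound 3 gives > 100000 nM, again a limit.

Compound 3 therefore stands at the assay limit, as do the other two values: the limit of > 100000 nM in this assay, at which 3 of the 3 values shown sit. Within the data shown here, the only step between measured compounds, a step that the two limits leave unreadable from compound 1 to compound 3, is unreadable because the limit of > 100000 nM in this assay, at which 3 of the 3 values shown sit, caps both ends. Compound 4 `CC(C)N(Cc1ncnc2c1ncn2[C@@H]1O[C@H](CO)[C@@H](O)[C@H]1O)C(C)C` differs from compound 3 by diisopropylamino in place of methoxy on a saturated chain carbon bound to an aromatic carbon. Among the measured compounds shown here, no measured step bears on this change; the nearest parallel is compound 2, which carries a different substituted amino on the same chain carbon and sits at the limit. In this assay compound 4 is expected to follow, with a step that the limit leaves unreadable from compound 3 to compound 4 no step beyond the scatter, and an estimate of 150000 nM (range 50000 nM to 500000 nM), most likely again a limit.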

Compound 4, half-maximal cytotoxic concentration: 18000 nM
For compound 4 the middle estimate is 8.3-fold (0.92 log units) above the measured one; the whole stated range lies above it.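

In this assay, the place on a saturated chain carbon bound to an aromatic carbon now yields a readable change: diisopropylamino gives an at least 5.5-fold lower number from compound 3 to compound 4 (0.74 log units; beyond the scatter), and in place of benzylsulfanyl it gives an at least 5.5-fold lower number from compound 1 to compound 4 (0.74 log units; beyond the scatter). Both steps are minimum sizes, because one end of each is capped: the limit of > 100000 nM in this assay, at which 3 of the 4 values shown sit. The value of compound 2, > 100000 nM, is a limit, so a substituted amino group at this place does not on its own lower the number.

From the compounds shown here alone, whether a smaller amine such as dimethylamino, or a cyclic amine such as piperidine, would lower it too remains open.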